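Swapping 4-bromophenyl for 3-nitrophenyl on compound 3

This account rests on a few compounds, and the source may have more. Where it says the series, first, only, none or still open, it means among the compounds named here.

Compound 1 `COc1cc(/C=C2\CN(C)C/C(=C\c3cccc([N+](=O)[O-])c3)C2=O)cc(OC)c1` gives 2560 nM
Compound 2 `COc1cc(/C=C2\CN(C)C/C(=C\c3ccc(Cl)cc3)C2=O)cc(OC)c1OC` gives > 20000 nM, which is a limit
Compound 3 `COc1cc(/C=C2\CN(C)C/C(=C\c3ccc(Br)cc3)C2=O)cc(OC)c1OC` gives 11900 nM

All three values come from a functional assay on HeLa cells (Homo sapiens) for cytotoxicity, read by MTT assay, with a stated time of 24 h; on this read-out lower numbers stand for stronger inhibition and higher numbers for weaker inhibition. Of the two actual numbers, the higher belongs to compound 3, at 11900 nM. Compound 1 gives 2560 nM, lower by more than the usual scatter. Compound 2 reads > 20000 nM, a limit of the assay and not a number.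

Compound 4 `COc1cc(/C=C2\CN(C)C/C(=C\c3cccc([N+](=O)[O-])c3)C2=O)cc(OC)c1OC` has not yet been measured. Compared with compound 3, it has 3-nitrophenyl in place of 4-bromophenyl on a double-bonded chain carbon bound to a double-bonded ring carbon.

Among the compounds with values here, only one measured step bears on this group: an at least 1.6-fold lower number from compound 2 to compound 3 (0.22 log units; that floor lies within the scatter), with bromo in place of chloro on an aromatic carbon. That step lies within the scatter and starts from a limit, so it gives no size for the swap to 3-nitrophenyl. Within the data shown here, the only number for a compound with 3-nitrophenyl is that of compound 1, at 2560 nM, so a move towards lower numbers seems more likely than a move upwards. The expected change is modest and uncertain: a 2.4-fold lower number from compound 3 to compound 4 (0.38 log units; beyond the scatter). For compound 4 the estimate is 5000 nM, with an expected range from 1800 nM to 13000 nM.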

Compound 4, half-maximal inhibitory concentration: 5540 nM
Estimate against measurement, compound 4: 1.1-fold (0.04 log units) below, within the range that was stated.
By their numbers in this assay, from the lowest: compound 1; then compound 4; then compound 3. At a limit, above all of these: compound 2.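

In this assay, 3-nitrophenyl in place of 4-bromophenyl on a double-bonded chain carbon bound to a double-bonded ring carbon gives a measured change at this position that goes beyond the scatter (a 2.1-fold lower number from compound 3 to compound 4 (0.33 log units; beyond the scatter)), and the same group in place of 4-chlorophenyl points the same way, although that step gives only a floor and not a size (an at least 3.6-fold lower number from compound 2 to compound 4 (0.55 log units; beyond the scatter)). The other aromatic ring also matters: with 3-nitrophenyl held constant, methoxy in place of hydrogen on an aromatic carbon moves the number up by a similar amount (a 2.2-fold higher number from compound 1 to compound 4 (0.34 log units; beyond the scatter)), so the two single changes have sizes that can be set side by side, with opposite directions. Compound 2 remains at a limit of the assay, not at a number: (the limit of > 20000 nM in this assay, at which 1 of the 4 values shown sits).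

Going by these compounds, how an amine or a carboxylic acid in place of the nitro group on that phenyl ring would read stays open. The compounds shown also leave open whether the step for methoxy in place of hydrogen would keep its direction and size with 4-bromophenyl on the same chain carbon.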